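Sulfonamide ring swap in a quinoline series: clearance outlook

This account rests on a few compounds, and the source may have more. Where it says the series, first, only, none or still open, it means among the compounds named here.

Among the measured compounds shown here, compound 1 `Cc1cc(C(F)(F)F)c2cccc(OCc3c(Cl)ccc(S(=O)(=O)N4CCC[C@H]4C(N)=O)c3Cl)c2n1` is one of two compounds measured in an ADME assay on microsomes (Homo sapiens) for metabolic stability; a lower number here means slower removal, a higher number faster removal of the compound. Compound 1 gives 167 mL/min/kg, and compound 2 `Cc1cc(C(F)(F)F)c2cccc(OCc3c(Cl)ccc(S(=O)(=O)N4CCCC4)c3Cl)c2n1` gives 233 mL/min/kg; the two numbers lie within the scatter of each other, as the step of a 1.4-fold higher number from compound 1 to compound 2 (0.14 log units; within the scatter) shows, so neither can be called the more stable of the pair. Compound 3 `Cc1cc(C(F)(F)F)c2cccc(OCc3c(Cl)ccc(S(=O)(=O)N4CCC(CCO)CC4)c3Cl)c2n1` is unmeasured; it differs from compound 1 by the change (4-(2-hydroxyethyl)piperidin-1-yl in place of 2-carbamoylpyrrolidin-1-yl on a sulfonyl sulfur). For the measured compounds named here, no measured step covers this particular change; the only step at hand, a 1.4-fold higher number from compound 1 to compound 2 (0.14 log units; within the scatter), touches the same ring and moved the number little. On that basis compound 3 is expected to stay near the high clearance of compound 1 and compound 2, with an estimated step of a 1.3-fold higher number from compound 1 to compound 3 (0.10 log units; within the scatter) in this assay that need not pass the scatter. The estimate for compound 3 is 210 mL/min/kg, with a range from 110 mL/min/kg to 400 mL/min/kg.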

Compound 3, clearance: 367 mL/min/kg
Compound 3: middle estimate off by 1.7-fold (0.24 log units), on the low side; the range from low to high includes it.
By their numbers in this assay, from the lowest: compounds 1, 2 and 3 (each within the scatter of the next, the first and the last beyond it).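

Among the compounds shown here, the sulfonyl sulfur is not a silent position in this assay: replacing 2-carbamoylpyrrolidin-1-yl with 4-(2-hydroxyethyl)piperidin-1-yl gives the first step in this set to pass the scatter (a 2.2-fold higher number from compound 1 to compound 3 (0.34 log units; beyond the scatter)), although the size is modest. For the compounds shown here, the comparison with the unsubstituted pyrrolidin-1-yl does not separate the two compounds (a 1.6-fold higher number from compound 2 to compound 3 (0.20 log units; within the scatter)), so only the pair containing compound 1 shows a difference. No measured data on this result offer an explanation for the step.

Ring size and substituent both differ in the step from compound 1 to compound 3, so their separate contributions cannot be read. A plain piperidin-1-yl would separate them, while a carboxylic acid on the piperidine ring in place of the 2-hydroxyethyl chain remains an open test of the substituent.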